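Shrinking an amide substituent on a shared core

This account rests on a few compounds, and the source may have more. Where it says the series, first, only, none or still open, it means among the compounds named here.

Compound 1 `CCC1C(=O)N(C)c2cnc(Nc3ccc(S(=O)(=O)NC)cc3)nc2N1c1ccn(C)n1` gives 71.6 nM in an assay for inhibition of serine/threonine-protein kinase PLK2 (Homo sapiens), read by FRET and Z'-LYTE, with a stated time of 1 h; a higher number here means a weaker inhibitor, a lower number a stronger inhibitor.
Compound 2 `CCC1C(=O)N(C)c2cnc(Nc3ccc(S(=O)(=O)NCC(C)C)cc3)nc2N1c1ccn(C)n1` gives 311 nM in this assay.
Compound 3 `CCC1C(=O)N(C)c2cnc(-n3ccc4cc(C(=O)NC(C)C)ccc43)nc2N1c1ccn(C)n1` gives 125 nM in this assay.

Among these three, compound 3 stands second highest: its number sits within the scatter of that of compound 1, and beyond the scatter below that of compound 2. The new compound, compound 4 `CCC1C(=O)N(C)c2cnc(-n3ccc4cc(C(=O)NC)ccc43)nc2N1c1ccn(C)n1`, differs from compound 3 by methyl in place of isopropyl on an amide-type nitrogen, so the amide carries a smaller group.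

Among the measured compounds shown here, only one measured step speaks to a change of this sort. From compound 1 to compound 2, adding an isopropyl on a sulfonamide nitrogen gave a 4.3-fold higher number from compound 1 to compound 2 (0.64 log units; beyond the scatter). That step runs in the opposite sense (a group grows rather than shrinks), sits on a sulfonamide rather than an amide, and starts from hydrogen rather than methyl, so it bears only loosely here. Taking it as a rough guide, a smaller group on the amide nitrogen of compound 4 is expected to give a somewhat lower number in this assay, a step of about a 1.7-fold lower number from compound 3 to compound 4 (0.22 log units; within the scatter). Compound 4 is therefore estimated at 75 nM, with a range from 30 nM to 220 nM.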

Compound 4, half-maximal inhibitory concentration: 218 nM
The estimate for compound 4 lay 2.9-fold (0.46 log units) below the measured number; the measured number falls inside the stated range.
By their numbers in this assay, from the lowest: compounds 1, 3, 4 and 2 (each within the scatter of the next, the first and the last beyond it).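

On this amide nitrogen, trading isopropyl for methyl gave a 1.7-fold higher number from compound 3 to compound 4 (0.24 log units; within the scatter), so in this assay compound 3 and compound 4 cannot be told apart. Among the compounds shown here, removing two of the three carbons of this group therefore leaves no measurable mark on this pair, whereas the one earlier step, on the sulfonamide of a different series member, was a 4.3-fold higher number from compound 1 to compound 2 (0.64 log units; beyond the scatter) and did lie beyond the scatter. No other kind of measurement accompanies these numbers to account for the result.

This is a single pair, so it says little about how far the amide nitrogen tolerates change in general. Still open, as far as these compounds go, is whether a plain primary amide, a longer chain such as n-butyl, or a ring such as cyclohexyl on that nitrogen would separate clearly from compound 3.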